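A few compounds are considered here, and "the series" means these few. Any claim that something is new, unique, unknown or untested is made for them only; others in the source may bear on it.

Compound 1 `C=C(Br)C(=O)Nc1cccc(/C=C2\SC(=O)N(Cc3cccc(F)c3)C2=O)c1` and compound 2 `C=C(Br)C(=O)Nc1cccc(/C=C2\SC(=O)N(Cc3ccc(Cl)cc3)C2=O)c1` share a core and differ only at one site. In a functional assay on HeLa cells (Homo sapiens) for cytotoxicity, read by cell counting, with a stated time of 4 days (on this read-out higher numbers stand for weaker inhibition and lower numbers for stronger inhibition), compound 1 gives 2700 nM, and in this assay compound 2 gives 2700 nM. The change between them is 4-chlorophenyl in place of 3-fluorophenyl on a saturated chain carbon bound to an amide-type nitrogen in a ring, and it made no change at the digits printed from compound 1 to compound 2 (within the scatter).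

Compound 3 `Nc1ccc(/C=C2\SC(=O)N(Cc3cccc(F)c3)C2=O)cc1` carries a different core; the difference between the core of compound 3 and the core of compound 1 is not broken down here. In this assay compound 3 gives 250000 nM, which stands far from the values of compound 1 and compound 2, with both gaps well beyond the scatter.

Compound 4 `Nc1ccc(/C=C2\SC(=O)N(Cc3ccc(Cl)cc3)C2=O)cc1` has not been measured. For the measured compounds named here, it differs from compound 3 by 4-chlorophenyl in place of 3-fluorophenyl on a saturated chain carbon bound to an amide-type nitrogen in a ring, which is the same change as the one from compound 1 to compound 2, made at the same place. Because that earlier change produced no change at the digits printed from compound 1 to compound 2 (within the scatter), the expected step for compound 4 is likewise small, and the estimated change is no change at the digits printed from compound 3 to compound 4 (within the scatter). This expectation rests on a single measured pair and on the value of compound 3, so the uncertainty is wide, and the very high value of compound 3 leaves some chance that only a limit is reported. The estimate for compound 4 in this assay is 250000 nM, with a range from 100000 nM to 600000 nM.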

Compound 4, half-maximal inhibitory concentration: 77000 nM
For compound 4 the middle estimate is 3.2-fold (0.51 log units) above the measured one; the whole stated range lies above it.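

In this assay, the swap of 3-fluorophenyl for 4-chlorophenyl on a saturated chain carbon bound to an amide-type nitrogen in a ring did not carry over from one core to the other with the same result: the same change on two cores in this assay, no change at the digits printed (within the scatter) from compound 1 to compound 2 and a 3.2-fold lower number (0.51 log units; beyond the scatter) from compound 3 to compound 4, 3.2-fold (0.51 log units) apart, beyond the scatter of two such steps

On the core of compound 1 the swap left the printed numbers as they were, whereas a 3.2-fold lower number from compound 3 to compound 4 (0.51 log units; beyond the scatter) marks a modest but real step on the core of compound 3, so in this series the outcome of the swap depends on the core it is made on. This does not show why the two cores part ways, and it rests on one pair per core, so neither the size nor the direction of the step can be taken as a general rule for other cores.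

The swap also changes both the halogen and its place on the ring at once, so the compounds shown leave open which of the two accounts for the step on the core of compound 3. A plain phenyl or a 4-fluorophenyl on the same carbon, tested on both cores, would bear on this, and an acetamide in place of the bromoacrylamide would bear on how the cores themselves differ.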